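Alkyl variation on the saturated ring carbon: clearance notes

A few compounds are considered here, and "the series" means these few. Any claim that something is new, unique, unknown or untested is made for them only; others in the source may bear on it.

Measured compounds:
Compound 1 `CC[C@H]1c2cc(Cl)ccc2C(=O)N1c1cncc2c1CCC[C@H]2NC(C)=O` — in an ADME assay on microsomes from liver (Homo sapiens) for metabolic stability, read by LC-MS, using NADPH, with stated times of 10 min and 30 min (a lower number here means slower removal, a higher number faster removal of the compound), compound 1 gives only a limit, < 3.5 mL/min/kg.
Compound 2 `CCC1c2cc(Cl)ccc2C(=O)N1c1cccnc1` — in this assay compound 2 gives 6.6 mL/min/kg.
Compound 3 `O=C1c2ccc(Cl)cc2C(C2CC2)N1c1cccnc1` — in this assay compound 3 gives 9.4 mL/min/kg.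

Compound 3 holds the highest of the two actual numbers in this assay, but its nearest neighbour, compound 2, sits within the scatter of it, so no order between the two can be claimed. The third value belongs to compound 1 and is a limit rather than a number (the limit of < 3.5 mL/min/kg in this assay, at which 1 of the 3 values shown sits).

The next compound, compound 4 `CC1c2cc(Cl)ccc2C(=O)N1c1cccnc1`, differs from compound 3 in one place: methyl in place of cyclopropyl on a saturated ring carbon. Going by the values given here, the only measured step that bears on this position is a 1.4-fold higher number from compound 2 to compound 3 (0.15 log units; within the scatter), a change between two small alkyl groups that stayed within the scatter. Removing the three-membered ring for the smallest alkyl is a change of the same kind, so no step beyond the scatter is expected in this assay for compound 4, with a slight lean toward a lower number.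

Compound 4 is therefore expected to give about 7 mL/min/kg in this assay, between 3.5 mL/min/kg and 14 mL/min/kg, which means an expected step of a 1.3-fold lower number from compound 3 to compound 4 (0.13 log units; within the scatter).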

Compound 4, clearance: 12.2 mL/min/kg
Compound 4: middle estimate off by 1.7-fold (0.24 log units), on the low side, within the range that was stated.
By their numbers in this assay, from the lowest: compounds 2, 3 and 4 (each within the scatter of the next). At a limit, below all of these: compound 1.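

In this assay shortening the group on this saturated ring carbon to methyl leaves the number within the scatter of both neighbours, with a 1.3-fold higher number from compound 3 to compound 4 (0.11 log units; within the scatter) for cyclopropyl to methyl and a 1.8-fold higher number from compound 2 to compound 4 (0.27 log units; within the scatter) for ethyl to methyl on the same core. Methyl, ethyl and cyclopropyl at this position are thus all within the scatter of one another, so compound 2, compound 3 and compound 4 carry no order, and no effect of the group can be read across these three. Nothing at hand gives a cause for these steps.

Compound 1 gives < 3.5 mL/min/kg as a limit and differs from the others in more than one place, so it does not bear on this position. From the compounds shown here alone, whether an amine, a carboxylic acid or a longer chain here would leave the scatter in this assay stays open.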